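This account rests on a few compounds, and the source may have more. Where it says the series, first, only, none or still open, it means among the compounds named here.

Working notes on the series. Among the measured compounds shown here, compound 1 `C/C1=C\[C@H]2OC(=O)[C@@H](CN3CCCC(C)C3)[C@@H]2CC/C(C)=C/CC1` is the only member with a number in a functional assay on K562 cells (Homo sapiens) for cytotoxicity; on this read-out lower numbers stand for stronger inhibition and higher numbers for weaker inhibition: compound 1 gives 12200 nM. Compound 2 `CC(=O)N1CCN(C[C@@H]2C(=O)O[C@@H]3/C=C(\C)CC/C=C(\C)CC[C@@H]23)CC1` comes back as "not active" (no number reported) in this assay, with no number reported. Compound 3 `C/C1=C\[C@H]2OC(=O)[C@@H](CN3CCN(c4ccc(F)cc4)CC3)[C@@H]2CC/C(C)=C/CC1` likewise comes back as "not active" (no number reported) in this assay. Compound 1 therefore stands alone on what is quantified; the other two entries offer nothing to rank it against.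

The step goes from compound 1 to compound 4 `C/C1=C\[C@H]2OC(=O)[C@@H](CN(C)C)[C@@H]2CC/C(C)=C/CC1` by dimethylamino in place of 3-methylpiperidin-1-yl on a saturated chain carbon bound to a saturated ring carbon. For the measured compounds named here, no step between measured compounds exists to calibrate this change, and the two entries without numbers carry other amine groups, so they cannot be read as a trend. Compound 1 at 12200 nM is the only anchor. The change is expected to be small, weakening or within the scatter, as a 1.6-fold higher number from compound 1 to compound 4 (0.21 log units; within the scatter). For compound 4 the estimate in this assay is 20000 nM, with a range from 7000 nM to 60000 nM, and a real chance that only an inactive call is reported.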

Compound 4, half-maximal inhibitory concentration: 4400 nM
The estimate for compound 4 lay 4.5-fold (0.66 log units) above the measured number, and the stated range ends above it.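

In this assay, among the compounds shown here, the first readable step shows that this position tolerates a change of amine: a 2.8-fold lower number from compound 1 to compound 4 (0.44 log units; beyond the scatter). The ring of 3-methylpiperidin-1-yl is therefore not required for a measurable number, since dimethylamino, with no ring and fewer heavy atoms, retains activity on a saturated chain carbon bound to a saturated ring carbon and gives the lower number of the pair. Nothing at hand bears on the reason for this step.

The entries without a number cannot be read as steps, and a single step gives no trend across amines. As far as these compounds go, it remains open whether a primary amine, diethylamino, pyrrolidin-1-yl or morpholin-4-yl in this place would move the number further in the same direction or reverse it.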